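Cyano for methoxy on the phenyl of a triazole-linked cinnamic acid

The source may hold more compounds than are shown below. What is called first, only, known or untested is meant among the compounds shown, and "the series" means these compounds.

Measured compounds and their values:
- compound 2, `COc1ccc(/C=C\C(=O)O)c(OCc2cn(-c3ccccc3)nn2)c1CC=C(C)C`: 29200 nM
- compound 3, `COc1ccccc1-n1cc(COc2c(/C=C\C(=O)O)ccc(OC)c2CC=C(C)C)nn1`: 41500 nM
- compound 1, `COc1ccc(/C=C\C(=O)O)c(OCc2cn(-c3ccccc3C(=O)N3CCC(O)C3)nn2)c1CC=C(C)C`: "not determined" (no result reported)

All four compounds share one core and differ only on the phenyl ring attached to the triazole. In a functional assay on NCI-H322 cells (Homo sapiens) for cytotoxicity, read by MTT assay, with a stated time of 24 h (a lower number here means a stronger inhibitor, a higher number a weaker inhibitor), compound 2 gives 29200 nM and compound 3 gives 41500 nM. Among the compounds with values here, the only single-point step known, a 1.4-fold higher number from compound 2 to compound 3 (0.15 log units; within the scatter), falls within the scatter, so the two cannot be told apart. Compound 3 holds the higher of the two numbers, but only by a margin the assay cannot resolve; in this assay compound 1 gives "not determined" (no result reported).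

Compound 4, `COc1ccc(/C=C\C(=O)O)c(OCc2cn(-c3ccccc3C#N)nn2)c1CC=C(C)C`, differs from compound 3 by cyano in place of methoxy on an aromatic carbon.

Within the data shown here, no measured step swaps one of these groups for another on this carbon; the one step known, from compound 2 to compound 3, places a methoxy where hydrogen was and stays within the scatter. With so little to go on, nothing beyond the scatter is expected in this assay from the change to cyano, and the estimate for compound 4 is a step of a 1.2-fold lower number from compound 3 to compound 4 (0.06 log units; within the scatter).

Compound 4 is therefore expected to give about 36000 nM in this assay, with a plausible range from 12000 nM to 100000 nM.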

Compound 4, half-maximal inhibitory concentration: 14400 nM
For compound 4 the middle estimate is 2.5-fold (0.40 log units) above the measured one, within the range that was stated.
By their numbers in this assay, from the lowest: compound 4; then compounds 2 and 3 (each within the scatter of the next).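

In this assay, the group on this carbon of the phenyl ring can move the number beyond the scatter: cyano in place of methoxy is a step of a 2.9-fold lower number from compound 3 to compound 4 (0.46 log units; beyond the scatter), while methoxy in place of hydrogen was a step of only a 1.4-fold higher number from compound 2 to compound 3 (0.15 log units; within the scatter). Cyano also stands apart from plain hydrogen at the same carbon, with a step of a 2.0-fold lower number from compound 2 to compound 4 (0.31 log units; beyond the scatter), which makes compound 4 the strongest of the three compounds with a number here, although both of its steps are modest. No measurement shown here accounts for this difference between the groups, so it stands as an observation without an explanation.

As far as these compounds go, with numbers for only hydrogen, methoxy and cyano on this carbon, it remains open whether the lower number is specific to cyano or would also appear with another group, such as a fluorine atom, a trifluoromethyl group, an amine or a carboxylic acid. From the compounds shown here alone, it is also open whether cyano would give a similar step at another carbon of the same ring.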